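Aryl ether side chain variation on the shared core

The compounds below may be only part of what the source reports. "The series", "measured", "known", "first", "only" and "open" are said of these compounds alone.

Compound 2 `CCC#CCOc1cccc2ccc(N)nc12` in an assay on cells with melanin-concentrating hormone receptor 1 (Homo sapiens) as the target, read by radioligand binding (a higher number here means a weaker inhibitor, a lower number a stronger inhibitor), gives > 2000 nM; this is a limit of the assay and not a number, as noted at the limit of > 2000 nM in this assay, at which 1 of the 2 values shown sits. Compound 1 `Nc1ccc2cccc(OCC3CCCC3)c2n1` in this assay gives 53 nM. Among the measured compounds shown here, the one measured step, an at least 37-fold higher number from compound 1 to compound 2 (1.57 log units; beyond the scatter), is the only comparison that bears on the next change. Compound 3 `CC(C)(C)CCOc1cccc2ccc(N)nc12` has not yet been measured in this assay; it differs from compound 2 by neopentyl in place of but-1-yn-1-yl on a saturated chain carbon bound to an oxygen on an aromatic ring. The entering neopentyl is a saturated branched group, closer in kind to the cyclopentyl of compound 1 than to the leaving but-1-yn-1-yl, which is the group whose entry in an at least 37-fold higher number from compound 1 to compound 2 (1.57 log units; beyond the scatter) brought the large step. Compound 2 sits only at a limit, and the size of any return cannot be fixed from that side; compound 1 gives the other bound. Compound 3 is expected to fall between the two measured points, with a step of an at least 6.6-fold lower number from compound 2 to compound 3 (0.82 log units; beyond the scatter) toward stronger inhibition. The estimate for compound 3 is 300 nM, within a range from 60 nM to 2000 nM.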

Compound 3, half-maximal inhibitory concentration: 201 nM
Beside the measured number, compound 3's estimate is 1.5-fold (0.17 log units) above it, within the range that was stated.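

In this assay, the side chain on a saturated chain carbon bound to an oxygen on an aromatic ring does not need a ring for measurable inhibition: neopentyl in place of but-1-yn-1-yl gives an at least 9.9-fold lower number from compound 2 to compound 3 (0.99 log units; beyond the scatter). The open-chain group does not match the ring, however, as neopentyl in place of cyclopentyl gives a 3.8-fold higher number from compound 1 to compound 3 (0.58 log units; beyond the scatter), so these two saturated groups are not interchangeable at this position. Compound 2 remains a limit of the assay and not a number, so the first step has a bound rather than an exact size: the limit of > 2000 nM in this assay, at which 1 of the 3 values shown sits.

The compounds shown do not separate the loss of the triple bond from the gain of branching, which a straight pentyl chain in place of pent-2-yn-1-yl would address, and they do not show whether the ring itself sets compound 1 apart, which cyclobutyl or cyclohexyl in place of cyclopentyl would test. Also open, going by these compounds, is how a side chain ending in an amine or a hydroxyl group would read in this assay.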